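Methyl in place of isopropyl next to the ring oxygen

This account rests on a few compounds, and the source may have more. Where it says the series, first, only, none or still open, it means among the compounds named here.

For the measured compounds named here, compound 3 `CC(C)c1oc(C(=O)O)cc1COc1ccc(-c2ccccc2)cc1` gives 3000 nM in an assay on cells for displacement of a labelled ligand from prostaglandin E2 receptor EP4 subtype (Homo sapiens), read by scintillation counting (on this read-out lower numbers stand for stronger inhibition and higher numbers for weaker inhibition), the highest of the three numbers measured so far. Compound 1 `COc1ccccc1-c1ccc(OCc2cc(C(=O)O)oc2C)cc1` gives 1600 nM, within the scatter of compound 3; compound 2 `COc1ccc(-c2ccc(OCc3cc(C(=O)O)oc3C)cc2)nc1` gives 1300 nM, beyond the scatter from compound 3. Going by the values given here, the only measured step, a 1.2-fold lower number from compound 1 to compound 2 (0.09 log units; within the scatter), concerns the aryl end and does not touch the change considered here. Compound 4 `Cc1oc(C(=O)O)cc1COc1ccc(-c2ccccc2)cc1` differs from compound 3 by methyl in place of isopropyl on an aromatic carbon. Among the compounds with values here, no measured step bears directly on this change; compounds 1 and 2 carry the methyl already, but their aryl ends differ from that of compound 3, so they serve only as a rough anchor. No step beyond the scatter is therefore expected; the estimated step is a 1.2-fold lower number from compound 3 to compound 4 (0.08 log units; within the scatter). Compound 4 is expected to give 2500 nM, with a range from 800 nM to 8000 nM.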

Compound 4, inhibition constant: 420 nM
For compound 4 the middle estimate is 6.0-fold (0.77 log units) above the measured one; measured number below the stated range.
By their numbers in this assay, from the lowest: compound 4; then compounds 2, 1 and 3 (each within the scatter of the next, the first and the last beyond it).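

In this assay, the position next to the ring oxygen responds clearly: methyl in place of isopropyl gives a real step (a 7.1-fold lower number from compound 3 to compound 4 (0.85 log units; beyond the scatter)). With methyl held, the aryl end also counts, as hydrogen in place of methoxy (a 3.8-fold lower number from compound 1 to compound 4 (0.58 log units; beyond the scatter)) and phenyl in place of 5-methoxypyridin-2-yl (a 3.1-fold lower number from compound 2 to compound 4 (0.49 log units; beyond the scatter)) both go beyond the scatter. Nothing available explains these steps.

Still open, going by these compounds, is how hydrogen, ethyl or hydroxymethyl would read at this position. Also open, on these data alone, is whether isopropyl gives a similar step with the aryl ends of compound 1 and compound 2.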